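The source may hold more compounds than are shown below. What is called first, only, known or untested is meant among the compounds shown, and "the series" means these compounds.

Notes on the series. Three compounds share one core and differ only at the amide nitrogen. Compound 1 `COc1cc2c(cc1OC)C(CC(=O)N(C)C)CC2` carries a dimethylamino group on the carbonyl carbon; in a functional assay on the whole organism (strain Wistar) for inhibition, with Rattus norvegicus as the target, read by paw edema, with stated times of 60 min and 4 h, at a dose of 100 mg/kg by the oral route (on this read-out lower numbers stand for less inhibition and higher numbers for more inhibition at the one dose given (going by the name of the read-out)), compound 1 gives 35.9%. Compound 2 `CCNC(=O)CC1CCc2cc(OC)c(OC)cc21` carries an ethylamino group there, and compound 2 gives 26.6%. Compound 3 `COc1cc2c(cc1OC)C(CC(=O)NC1CCCC1)CC2` carries a cyclopentylamino group, and compound 3 gives 45.3%, the highest of the three numbers, though the gap to compound 1 is within the scatter and only the gap to compound 2 is beyond it.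

The measured steps: a number 9.3 percentage points lower from compound 1 to compound 2 (within the scatter); a number 9.4 percentage points higher from compound 1 to compound 3 (within the scatter); a number 18.7 percentage points higher from compound 2 to compound 3 (beyond the scatter). Among the measured compounds shown here, replacing the dimethylamino group by a secondary amide thus moves the number within the scatter in either direction, and the only step beyond the scatter is the exchange of ethyl for cyclopentyl on the amide nitrogen.

Compound 4 `COc1cc2c(cc1OC)C(CC(=O)N1CCCC1)CC2` is unmeasured. It differs from compound 3 in one place: pyrrolidin-1-yl in place of cyclopentylamino on a carbonyl carbon. The two steps that bear on it, from compound 1 to compound 2 and from compound 1 to compound 3, each compare a tertiary amide with a secondary one and both lie within the scatter, so no step beyond the scatter is expected here; the five-membered ring is kept. The estimated step of a number 5.3 percentage points lower from compound 3 to compound 4 (within the scatter) is expected to stay within the scatter. For compound 4 the value in this assay is estimated at 40%, expected to fall between 26% and 54%.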

Compound 4, a percentage reported as inhibition, in the whole organism at one dose (the size of the read-out at that dose, not a potency): 24.2%
Estimate against measurement, compound 4: 15.8 percentage points above, outside the stated range (below it).
By their numbers in this assay, from the lowest: compounds 4, 2, 1 and 3 (each within the scatter of the next, the first and the last beyond it).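

Notes on the result. Pyrrolidin-1-yl in place of cyclopentylamino on a carbonyl carbon gives a number 21.1 percentage points lower from compound 3 to compound 4 (beyond the scatter) in this assay and is the first exchange of a secondary for a tertiary amide at this position to go beyond the scatter, so keeping a five-membered ring does not keep the number. Pyrrolidin-1-yl in place of dimethylamino gives a number 11.7 percentage points lower from compound 1 to compound 4 (beyond the scatter) and shows that two groups with no hydrogen-bond donor can also differ beyond the scatter, while pyrrolidin-1-yl in place of ethylamino gives a number 2.4 percentage points lower from compound 2 to compound 4 (within the scatter) and places a group without a donor within the scatter of one with a donor, so among compounds 1 to 4 the donor count does not sort the numbers. Nothing available explains these differences.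

As far as these compounds go, it remains open how piperidin-1-yl or morpholin-4-yl on the carbonyl carbon would compare with pyrrolidin-1-yl, and whether cyclohexylamino would give a number closer to that of cyclopentylamino. From the compounds shown here alone, with a single oral dose behind each number, the size of these steps at other doses also remains open.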